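Dog half-life across an isoxazole-amine series

The source may hold more compounds than are shown below. What is called first, only, known or untested is meant among the compounds shown, and "the series" means these compounds.

Measured compounds:
- compound 1 `Cc1ccc(NS(=O)(=O)Cc2ccc(Br)cc2)c(=O)n1CC(=O)NCc1ccc2c(N)noc2c1`: 1.82 h
- compound 2 `Cc1cnc(NCC2(c3ccccc3)CCC2)c(=O)n1CC(=O)NCc1ccc2c(N)noc2c1`: 1.95 h
- compound 3 `COc1cccc(S(=O)(=O)Nc2cccn(CC(=O)NCc3ccc4[nH]nc(N)c4c3)c2=O)c1`: 4.57 h

In an in vivo ADME assay on the whole organism with Canis familiaris (Canis lupus familiaris) as the target (a higher number here means that the compound lasts longer, a lower number that the compound disappears faster), compound 2 gives 1.95 h. This is the second highest of the three numbers. Its nearest neighbour is compound 1, which in this assay gives 1.82 h, a gap that lies within the scatter, so nothing separates these two. The furthest is compound 3, which in this assay gives 4.57 h, a gap beyond the scatter.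

Compound 4 `Cc1cnc(NCC2(c3ccc(F)cc3)CC2)c(=O)n1CC(=O)NCc1ccc2c(N)noc2c1` has not been measured. It differs from compound 2 in one place: 1-(4-fluorophenyl)cyclopropyl in place of 1-phenylcyclobutyl on a saturated chain carbon bound to a nitrogen on an aromatic ring. Among the compounds with values here, no step between two measured compounds maps onto this change, so there is no direct basis for a direction. The three measured compounds themselves span only a modest range in this assay. The expectation is therefore a step of no more than the scatter in either direction, and compound 4 is estimated to give 2.2 h in this assay, with a range from 1 h to 5 h, which means an expected step of a 1.1-fold higher number from compound 2 to compound 4 (0.05 log units; within the scatter).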

Compound 4, half-life: 2.17 h
For compound 4 the middle estimate is 1.0-fold (0.01 log units) above the measured one; the range from low to high includes it.
By their numbers in this assay, from the lowest: compounds 1, 2 and 4 (each within the scatter of the next); then compound 3.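

In this assay, the swap on a saturated chain carbon bound to a nitrogen on an aromatic ring gives a 1.1-fold higher number from compound 2 to compound 4 (0.05 log units; within the scatter), so this first one-place comparison in the set leaves the two compounds indistinguishable. The change alters two things at once, a four-membered ring becoming a three-membered ring and a fluorine entering on the six-membered aromatic ring, and together these leave no readable mark on the half-life. Nothing available explains this outcome.

The compounds shown do not separate the two alterations, which 1-phenylcyclopropyl or 1-(4-fluorophenyl)cyclobutyl at this place would do. They also leave open whether a group of another kind here, such as an amine or a carboxylic acid, would give a step beyond the scatter.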